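Predicting Compound 3 from Two Limit-Only Analogues

The compounds below may be only part of what the source reports. "The series", "measured", "known", "first", "only" and "open" are said of these compounds alone.

Compound 1 `NC1(CCn2ncc(=O)[nH]c2=O)OC(=O)C(OCc2ccccc2)=C1OCc1ccccc1` and compound 2 `Nc1ccn(CCC2(N)OC(=O)C(OCc3ccccc3)=C2OCc2ccccc2)c(=O)n1` share the same core and differ only in the ring attached to the short chain. In a functional assay on HeLa cells (Homo sapiens) for inhibition, read by MTT assay, with a stated time of 72 h (on this read-out lower numbers stand for stronger inhibition and higher numbers for weaker inhibition), compound 1 gives > 100000 nM, which is a limit of the assay and not a number. In this assay compound 2 gives > 100000 nM, again a limit and not a number. The step that the two limits leave unreadable from compound 1 to compound 2 therefore cannot be sized. On the numbers shown, compound 2 stands at the limit, with no measured value to place it relative to any neighbour.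

Compound 3 `NC1(CCn2c(=O)[nH]c(=O)[nH]c2=O)OC(=O)C(OCc2ccccc2)=C1OCc1ccccc1` introduces the next change: a group of 9 heavy atoms (3 carbon, 3 nitrogen, 3 oxygen; one six-membered aromatic ring with 3 hetero atoms) in place of a group of 8 heavy atoms (4 carbon, 3 nitrogen, 1 oxygen; one six-membered aromatic ring with 2 hetero atoms), on a saturated chain carbon, two bonds along the chain from a saturated ring carbon. Within the data shown here, the only measured step, a step that the two limits leave unreadable from compound 1 to compound 2, is unreadable, so it offers no direction or size for this new change.

Because (the limit of > 100000 nM in this assay, at which 2 of the 2 values shown sit), compound 3 is expected to remain at the limit in this assay rather than return a number. Compound 3 is accordingly estimated at 150000 nM, with a range from 50000 nM to 500000 nM. The expected step that the limit leaves unreadable from compound 2 to compound 3 amounts to no change beyond the scatter.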

Compound 3, half-maximal inhibitory concentration: 77100 nM
Compound 3: middle estimate off by 1.9-fold (0.29 log units), on the high side, within the range that was stated.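

Of the compounds shown, only compound 3 returns a measured number, so the ring on a saturated chain carbon, two bonds along the chain from a saturated ring carbon, can now be tied to a readable result: in this assay compound 3 gives 77100 nM. Exchanging the ring with 2 hetero atoms for the ring with 3 hetero atoms and 3 double bonds outside aromatic rings gives an at least 1.2-fold lower number from compound 2 to compound 3 (0.11 log units; that floor lies within the scatter), and the change between the two rings with 3 hetero atoms gives an at least 1.2-fold lower number from compound 1 to compound 3 (0.11 log units; that floor lies within the scatter). Each step is only a floor, so the measured number does not by itself establish a real gain in inhibition over either neighbour.

On these data alone, the true size of both steps stays open: the limit of > 100000 nM in this assay, at which 2 of the 3 values shown sit. The compounds shown also leave open whether an amine or a carboxylic acid in place of the ring, or a longer chain carrying the same ring as compound 3, would bring the number lower in this assay.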